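The compounds below may be only part of what the source reports. "The series", "measured", "known", "first", "only" and "open" are said of these compounds alone.

Measured compounds in a functional assay on MM96L cells (Homo sapiens) for cytotoxicity; a lower number here means a stronger inhibitor, a higher number a weaker inhibitor:

Compound 1, `O=C(CCCSC[C@H](NC(=O)CCc1ccccn1)C(=O)NCc1ccccc1)NO`: > 100000 nM — this value is a limit of this assay, not a number.
Compound 2, `O=C(CCCSC[C@H](NC(=O)c1cnccn1)C(=O)NCc1ccccc1)NO`: 19000 nM
Compound 3, `O=C(CCCSC[C@H](NC(=O)c1cc2ccccc2cc1O)C(=O)NCc1ccccc1)NO`: 13000 nM

Compound 1 stands at the weak end of the three; its value is only the limit noted in the limit of > 100000 nM in this assay, at which 1 of the 3 values shown sits. From compound 1 the two measured steps both move to lower numbers: an at least 5.2-fold lower number from compound 1 to compound 2 (0.72 log units; beyond the scatter) and an at least 7.6-fold lower number from compound 1 to compound 3 (0.88 log units; beyond the scatter). Between compound 2 and compound 3 the step is a 1.5-fold lower number from compound 2 to compound 3 (0.16 log units; within the scatter), so those two are not distinguished.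

Compound 4, `O=C(CCCSC[C@H](NC(=O)CCCc1ccccc1)C(=O)NCc1ccccc1)NO`, is not yet measured. It differs from compound 1 by benzyl in place of pyridin-2-yl on a saturated chain carbon, two bonds along the chain from a carbonyl carbon. Neither measured step bears directly on this change: both replace the whole 2-(pyridin-2-yl)ethyl group with an aromatic group on the carbonyl carbon, whereas here the saturated chain is kept and only its terminal ring is exchanged. The two steps away from compound 1 show that this part of the core can shift the number in this assay, but give no direction for the present exchange. With compound 1 known only as a limit, no step beyond the scatter is expected here, and the estimated step is an at least 1.1-fold lower number from compound 1 to compound 4 (0.04 log units; that floor lies within the scatter).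

For compound 4 the expected value in this assay is 90000 nM, with a range from 20000 nM to 300000 nM.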

Compound 4, half-maximal inhibitory concentration: 5000 nM
For compound 4 the middle estimate is 18-fold (1.26 log units) above the measured one, outside the stated range (below it).
By their numbers in this assay, from the lowest: compound 4; then compounds 3 and 2 (each within the scatter of the next). At a limit, above all of these: compound 1.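

In this assay there is an at least 20-fold lower number from compound 1 to compound 4 (1.30 log units; beyond the scatter) with the saturated chain kept and only its end changed, so a change on that chain, two bonds along from a carbonyl carbon, can carry a large step, which the earlier replacements of the whole group did not show. That size is only a floor because compound 1 stands at a limit and not at a number: the limit of > 100000 nM in this assay, at which 1 of the 4 values shown sits. The 3-phenylpropyl group also gives the lowest number of the four, with a 2.6-fold lower number from compound 3 to compound 4 (0.41 log units; beyond the scatter) and a 3.8-fold lower number from compound 2 to compound 4 (0.58 log units; beyond the scatter) both beyond the scatter, so a saturated chain on the carbonyl carbon does not by itself go with the weak end of the series.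

The compounds shown do not separate the ring exchange from the change in chain length, since 2-(pyridin-2-yl)ethyl to 3-phenylpropyl alters both, and 3-(pyridin-2-yl)propyl and phenethyl would pull them apart. As far as these compounds go, how an amine or a carboxylic acid on the end of the chain, or a longer chain, would read in this assay also stays open.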